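Swapping the Aryl Group on the Saturated Ring

The source may hold more compounds than are shown below. What is called first, only, known or untested is meant among the compounds shown, and "the series" means these compounds.

Of the compounds shown here, three built on a shared core have been measured in an assay on isolated protein for inhibition of Rho-associated protein kinase 2 (Homo sapiens), read by a luciferase reporter; on this read-out lower numbers stand for stronger inhibition and higher numbers for weaker inhibition. Compound 1 `O=C(Nc1cc2cc[nH]c(=O)c2cc1Cl)C1CNCC1c1ccc(F)cc1` gives 9 nM. Compound 2 `NC(C(=O)Nc1cc2cc[nH]c(=O)c2cc1Cl)c1cccc(Cl)c1`, which lacks the five-membered non-aromatic ring, gives 15 nM. Compound 3 `O=C(Nc1cc2cc[nH]c(=O)c2cc1Cl)C1CNCC1c1ccc(Cl)cc1Cl` gives 8 nM. Compound 3 sits at the lower end of these three numbers, but its gap to compound 1 and its gap to compound 2 both fall within the usual scatter of repeated measurements, so on this read-out the three compounds cannot be told apart.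

Compound 4 `O=C(Nc1cc2cc[nH]c(=O)c2cc1Cl)C1CNCC1c1cccc(Br)c1` has not yet been measured. It differs from compound 3 in one place: 3-bromophenyl in place of 2,4-dichlorophenyl on a saturated ring carbon. Among the compounds with values here, only one measured step speaks to this kind of change, the earlier swap on the same saturated ring carbon that gave a 1.1-fold lower number from compound 1 to compound 3 (0.05 log units; within the scatter). That step stayed within the scatter, so changing the aromatic group on that carbon appears to leave the number almost untouched, at least between those two compounds. A similarly small move is expected here. Compound 4 is therefore estimated at 10 nM, with a range from 4 nM to 25 nM, which corresponds to an expected step of a 1.3-fold higher number from compound 3 to compound 4 (0.10 log units; within the scatter).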

Compound 4, half-maximal inhibitory concentration: 2 nM
Compound 4: the middle estimate sits 5.0-fold (0.70 log units) above what was measured; measured number outside the range, below it.
By their numbers in this assay, from the lowest: compound 4; then compounds 3, 1 and 2 (each within the scatter of the next).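

Replacing 2,4-dichlorophenyl with 3-bromophenyl on this saturated ring carbon gives a 4.0-fold lower number from compound 3 to compound 4 (0.60 log units; beyond the scatter) in this assay, and replacing 4-fluorophenyl with 3-bromophenyl gives a 4.5-fold lower number from compound 1 to compound 4 (0.65 log units; beyond the scatter). The earlier swap at this carbon, a 1.1-fold lower number from compound 1 to compound 3 (0.05 log units; within the scatter), stayed within the scatter and so gave no sign that the aromatic group here could matter, but these two steps show that it can, with compound 4 standing apart from both compound 1 and compound 3. Nothing available here accounts for the effect of 3-bromophenyl on this number.

The change to 3-bromophenyl alters the halogen, the number of halogens and their arrangement on the aromatic ring all at once, so the compounds shown cannot say which of these differences matters; 3-chlorophenyl, 4-bromophenyl and plain phenyl at this carbon would help to pull them apart. On these data alone, it also remains open how far this carbon accepts aromatic rings carrying something other than a halogen, such as a methoxy group, an amine or a carboxylic acid.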